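Swapping Butyl for Cyclopentyl in an Antiproliferative Series

A few compounds are considered here, and "the series" means these few. Any claim that something is new, unique, unknown or untested is made for them only; others in the source may bear on it.

Three compounds have been measured in a functional assay on NCI-H460 cells (Homo sapiens) for antiproliferative activity, read by CCK-8 assay, with a stated time of 72 h, tested at 8 uM; a higher number here means a stronger effect of the compound at the concentration tested, a lower number a weaker effect:
compound 1, `CCCCn1cnc2c(Nc3cccc(Cl)c3)nc(NCOCc3ccc(/C=C/C(=O)Nc4ccccc4N)cc3)nc21`, gives 51.1%;
compound 2, `Cc1ccc(Nc2nc(Cl)nc3c2ncn3Cc2ccc(C(=O)Nc3ccccc3N)cc2)cc1`, gives 82.5%;
compound 3, `Nc1ccccc1NC(=O)/C=C/c1ccc(Cn2cnc3c(Nc4cccc(Cl)c4)nc(Cl)nc32)cc1`, gives 29.4%.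

Compound 1 stands second highest of these three numbers. Compound 3 lies lower by a gap beyond the usual scatter, and compound 2 lies higher by a larger gap, also beyond the scatter.

Compound 4, `Nc1ccccc1NC(=O)/C=C/c1ccc(COCNc2nc(Nc3cccc(Cl)c3)c3ncn(C4CCCC4)c3n2)cc1`, has not yet been measured in this assay. It differs from compound 1 in one place: cyclopentyl in place of butyl on an aromatic nitrogen. Going by the values given here, no measured pair in this set shows the effect of such a change, so its direction cannot be read from the data. The step of a number 1.1 percentage points lower from compound 1 to compound 4 (within the scatter) is expected to stay within the scatter. Compound 4 is therefore estimated at 50%, between 32% and 68%.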

Compound 4, a percentage reported as inhibition, at one concentration (the size of the read-out at that concentration, not a potency): 46.1%
The estimate for compound 4 lay 3.9 percentage points above the measured number, and the stated range covers the measured number.
By their numbers in this assay, from the lowest: compound 3; then compounds 4 and 1 (each within the scatter of the next); then compound 2.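

In this assay, going by these compounds alone, the swap of butyl for cyclopentyl on the aromatic nitrogen gives a number 5 percentage points lower from compound 1 to compound 4 (within the scatter), the first direct reading of a change at this position. In this one pair, an open chain and a five-membered carbon ring can therefore be exchanged there with no difference that stands out from the scatter. Nothing shown gives a measured reason for this result. Still open, as far as these compounds go, is how a methyl, a longer chain such as hexyl, or a ring containing nitrogen such as piperidine would fare at this position. A single pair also cannot show whether the same swap behaves alike on a different core.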